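The source may report more compounds than this note shows. Statements on the series, on what has been measured and on what is new or still open speak of the compounds shown alone.

Compound 1 `COc1cc2ncnc(N3CCc4ccccc43)c2cc1NC(=O)/C=C/CN1CCN(C)CC1` and compound 2 `COc1cc2ncnc(N3CCc4ccccc43)c2cc1NC(=O)/C=C/CN1CCC(CO)CC1` share one core, while compound 3 `CN1CCN(C/C=C/C(=O)Nc2cc3c(N4CCCc5ccccc54)ncnc3cc2O[C@@H]2CCOC2)CC1` and compound 4 `O=C(/C=C/CN1CCC(CO)CC1)Nc1cc2c(N3CCCc4ccccc43)ncnc2cc1O[C@@H]1CCOC1` share another; the difference between the two cores is not broken down here. In a functional assay on MCF7 cells (Homo sapiens) for antiproliferative activity, read by MTT assay, with a stated time of 72 h (a lower number here means a stronger inhibitor, a higher number a weaker inhibitor), compound 1 gives 6430 nM. In the same this assay compound 2 gives 2620 nM, and compound 3 gives 7180 nM. Compound 2 differs from compound 1 by 4-(hydroxymethyl)piperidin-1-yl in place of 4-methylpiperazin-1-yl on a saturated chain carbon bound to a double-bonded chain carbon, and that change brought a 2.5-fold lower number from compound 1 to compound 2 (0.39 log units; beyond the scatter). The same change, (4-(hydroxymethyl)piperidin-1-yl in place of 4-methylpiperazin-1-yl on a saturated chain carbon bound to a double-bonded chain carbon), carries compound 3 to compound 4, at the same place in both pairs. Compound 4 has not yet been tested in this assay. Because this change brought a 2.5-fold lower number from compound 1 to compound 2 (0.39 log units; beyond the scatter), compound 4 is expected to show a 2.5-fold lower number from compound 3 to compound 4 (0.39 log units; beyond the scatter). The estimate for compound 4 in this assay is 2900 nM, with a likely span from 1400 nM to 6000 nM; the expectation rests on a single earlier pair, so the span is kept wide.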

Compound 4, half-maximal inhibitory concentration: 4960 nM
Estimate against measurement, compound 4: 1.7-fold (0.23 log units) below, and the stated range covers the measured number.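

On the second core, putting 4-(hydroxymethyl)piperidin-1-yl in place of 4-methylpiperazin-1-yl gave, in this assay, a 1.4-fold lower number from compound 3 to compound 4 (0.16 log units; within the scatter), so on this core alone the change cannot be told apart from the scatter of repeated measurements. Set beside the earlier step on the first core, the new step does not differ measurably from it: the same change on two cores in this assay, a 2.5-fold lower number (0.39 log units; beyond the scatter) from compound 1 to compound 2 and a 1.4-fold lower number (0.16 log units; within the scatter) from compound 3 to compound 4, 1.7-fold (0.23 log units) apart, within the scatter of two such steps. This fits a change that carries from one core to the other, but it does not show a real gain on the second core, and two pairs cannot establish a rule for the whole series.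

The compounds shown leave open how the two parts of this change contribute, which 4-methylpiperidin-1-yl or plain piperidin-1-yl at the same place could help to separate. They also leave open whether other amines there, such as morpholin-4-yl or dimethylamino, would behave alike on either core.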